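A fluorinated pyridine ring replaces the ethylphenyl group

A few compounds are considered here, and "the series" means these few. Any claim that something is new, unique, unknown or untested is made for them only; others in the source may bear on it.

Compound 3 `CCc1ccccc1-c1cc2c(cn1)ncn2-c1ccc(OC(F)F)cc1` was examined in a functional assay on HL-60 cells (Homo sapiens) for activation, read by flow cytometry, with a stated time of 4 days (a higher number here means that more compound is needed for the effect, a lower number that less compound is needed), where compound 3 gives 2900 nM. Of the three measured compounds it holds the second highest number. Compound 1 `COc1cc(F)ccc1-c1cc2c(cn1)ncn2-c1ccc(OC(F)F)cc1` gives 93 nM in this assay, and compound 2 `FC(F)Oc1ccc(-n2cnc3cnc(-c4ccccc4OC(F)(F)F)cc32)cc1` gives 6900 nM. The step of a 31-fold higher number from compound 1 to compound 3 (1.49 log units; beyond the scatter) went with 2-ethylphenyl in place of 4-fluoro-2-methoxyphenyl, and the step of a 2.4-fold lower number from compound 2 to compound 3 (0.38 log units; beyond the scatter) with ethyl in place of trifluoromethoxy; both concern the same aromatic ring that is altered here. Compound 4 `Cc1cc(F)ncc1-c1cc2c(cn1)ncn2-c1ccc(OC(F)F)cc1` differs from compound 3 as follows: a group of 8 heavy atoms (6 carbon, 1 nitrogen, 1 fluorine; one six-membered aromatic ring with 1 hetero atom) in place of a group of 8 heavy atoms (8 carbon; one six-membered aromatic ring of carbon only), on an aromatic carbon. Both measured steps bear on this change, one large and one modest, and show that substitution on this ring can move the number widely in either direction. The entering ring carries 1 hydrogen-bond acceptor where 2-ethylphenyl had none, so a modest step toward a lower number is expected, with wide uncertainty. Compound 4 is therefore estimated to give about 1500 nM in this assay, within a range from 300 nM to 7000 nM. This estimate corresponds to an expected step of a 1.9-fold lower number from compound 3 to compound 4 (0.29 log units; within the scatter).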

Compound 4, half-maximal effective concentration: 1200 nM
Compound 4: the middle estimate sits 1.3-fold (0.10 log units) above what was measured; measured number inside the range.
By their numbers in this assay, from the lowest: compound 1; then compound 4; then compound 3; then compound 2.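

Placing a six-membered aromatic ring with 1 hetero atom at this position, where compounds 1, 2 and 3 all carry a ring of carbon only, gave a 2.4-fold lower number from compound 3 to compound 4 (0.38 log units; beyond the scatter) in this assay. The same replacement measured against the 4-fluoro-2-methoxyphenyl group gave a 13-fold higher number from compound 1 to compound 4 (1.11 log units; beyond the scatter), so the ring nitrogen does not by itself bring the number down to that of compound 1. Nothing available here explains either step.

The compounds shown leave open whether the ring nitrogen or the substituents on that ring account for the step, as none of them changes these one at a time. They also leave open how the number would respond to an amine or a carboxylic acid on the entering ring.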